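Trifluoromethyl added to the phenoxy ring of compound 1

The compounds below may be only part of what the source reports. "The series", "measured", "known", "first", "only" and "open" are said of these compounds alone.

Compound 1: `CC(CCNC(=O)c1c(Cl)cncc1Cl)N1CCC(C(Oc2ccccc2)c2ccc(C(F)(F)F)cc2)CC1`, an ADME assay on PBMC cells (Homo sapiens) for cytotoxicity; on this read-out lower numbers stand for higher toxicity in this test and higher numbers for lower toxicity in this test: 6800 nM
Compound 2: `CCO/N=C(/c1ccc(Br)cc1)C1CCN(C(C)CCNC(=O)c2c(C)cc[n+]([O-])c2C)CC1`, this assay: > 177000 nM (a limit of the assay)
Compound 3: `CC(CCNC(=O)c1c(Cl)cncc1Cl)N1CCC(C(Oc2ccccc2)c2ccc(Br)cc2)CC1`, this assay: 31700 nM
Compound 4: `CC(CCNC(=O)c1c(Cl)cncc1Cl)N1CCC(C(Oc2ccccc2C(F)(F)F)c2ccc(C(F)(F)F)cc2)CC1`, not yet measured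

Among the numbers shown, compound 1 stands lowest; its nearest neighbour is compound 3, reached by a 4.7-fold higher number from compound 1 to compound 3 (0.67 log units; beyond the scatter). Compound 2 gives only a limit in this assay, > 177000 nM, and the limit of > 177000 nM in this assay, at which 1 of the 3 values shown sits, is the sole such limit here.

Compound 4 differs from compound 1 in one place: trifluoromethyl in place of hydrogen on an aromatic carbon. Among the measured compounds shown here, the change sits ortho to a large group on the phenoxy ring, while the one measured step, from compound 1 to compound 3, alters a different ring and exchanges one group for another rather than adding one. No measured step therefore bears directly on the change to compound 4, and nothing shown tells how an added trifluoromethyl moves this read-out.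

Compound 4 is thus expected to stay close to compound 1, with a step of a 1.2-fold lower number from compound 1 to compound 4 (0.09 log units; within the scatter) that is not expected to exceed the scatter. The estimate for compound 4 is 5500 nM, with a range from 2000 nM to 16000 nM.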

Compound 4, half-maximal cytotoxic concentration: 12500 nM
Compound 4: middle estimate off by 2.3-fold (0.36 log units), on the low side; low and high end bracket the measured number.
By their numbers in this assay, from the lowest: compounds 1 and 4 (each within the scatter of the next); then compound 3. At a limit, above all of these: compound 2.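

In this assay, among the compounds shown here, the addition of trifluoromethyl to the phenoxy ring gives a 1.8-fold higher number from compound 1 to compound 4 (0.26 log units; within the scatter), the first reading of a change on that ring, and it leaves compound 1 and compound 4 indistinguishable. A trifluoromethyl ortho to a large group on this ring is therefore tolerated on this read-out without a shift beyond the scatter, whereas the exchange on the other aromatic ring, a 4.7-fold higher number from compound 1 to compound 3 (0.67 log units; beyond the scatter), does go beyond it. Nothing measured here offers a reason for either step.

From the compounds shown here alone, whether fluorine, a methoxy group or an amine at this place would read the same remains open, as does the effect of trifluoromethyl elsewhere on the phenoxy ring. Also open, going by these compounds, is whether the same addition to compound 3, with its bromo group, would give a similar step.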